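Pyrazolyl amine carried onto the aryl sulfonamide series

The source may hold more compounds than are shown below. What is called first, only, known or untested is meant among the compounds shown, and "the series" means these compounds.

In a functional assay on MCF7 cells (Homo sapiens) for antiproliferative activity, read by sulforhodamine B assay, with a stated time of 72 h (a higher number here means a weaker inhibitor, a lower number a stronger inhibitor), compound 1 `COc1ncc(-c2ccc3ncnc(Nc4ccc(OCCO)c(F)c4)c3c2)cc1NS(=O)(=O)c1ccc(F)cc1F` gives 4820 nM, the high end of the three numbers. Compound 3 `COc1ncc(-c2ccc3ncnc(Nc4ccc(OCCO)nc4)c3c2)cc1NS(=O)(=O)c1ccc(F)cc1F` gives 4300 nM; the step of a 1.1-fold lower number from compound 1 to compound 3 (0.05 log units; within the scatter) shows that exchanging one aryl group on the amine nitrogen for another stays within the scatter. Compound 2 `COc1ncc(-c2ccc3ncnc(Nc4cnn(CCCO)c4)c3c2)cc1NS(C)(=O)=O`, which carries the 1-(3-hydroxypropyl)-1H-pyrazol-4-yl group together with a methyl sulfonamide, gives 730 nM; it differs from compound 1 in two places, so its gap to compound 1 cannot be assigned to either change alone.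

Compound 4 `COc1ncc(-c2ccc3ncnc(Nc4cnn(CCCO)c4)c3c2)cc1NS(=O)(=O)c1ccc(F)cc1F` keeps the sulfonamide of compound 1 and carries the change (1-(3-hydroxypropyl)-1H-pyrazol-4-yl in place of 3-fluoro-4-(2-hydroxyethoxy)phenyl on a nitrogen on an aromatic ring). Among the measured compounds shown here, no measured step isolates this exchange. What bears on it: compound 2, which also holds the 1-(3-hydroxypropyl)-1H-pyrazol-4-yl group, sits well below compound 1, while the aryl-for-aryl swap from compound 1 to compound 3 stayed within the scatter. A move toward compound 2 is expected, taken as a 3.2-fold lower number from compound 1 to compound 4 (0.51 log units; beyond the scatter), with wide uncertainty. Compound 4 is estimated at 1500 nM, within 500 nM to 5000 nM.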

Compound 4, half-maximal inhibitory concentration: 1310 nM
Estimate against measurement, compound 4: 1.1-fold (0.06 log units) above; low and high end bracket the measured number.
By their numbers in this assay, from the lowest: compounds 2 and 4 (each within the scatter of the next); then compounds 3 and 1 (each within the scatter of the next).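

In this assay, the exchange on the nitrogen on an aromatic ring can now be read alone with the sulfonamide held constant: 1-(3-hydroxypropyl)-1H-pyrazol-4-yl improves on both aryl groups (a 3.7-fold lower number from compound 1 to compound 4 (0.57 log units; beyond the scatter)) and (a 3.3-fold lower number from compound 3 to compound 4 (0.52 log units; beyond the scatter)), each step beyond the scatter. Among the compounds shown here, the sulfonyl position can also be read alone for the first time, and with the pyrazolyl amine in place, 2,4-difluorophenyl and methyl on the sulfonyl sulfur are not separated (a 1.8-fold higher number from compound 2 to compound 4 (0.25 log units; within the scatter)). No measurement available here accounts for either result.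

Still open, from the compounds shown here alone, is whether the pyrazole ring or its 3-hydroxypropyl chain carries the step from the aryl groups. A shorter 2-hydroxyethyl chain or a terminal dimethylamine on the pyrazole would test that directly.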